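Pyrrolyl for methoxy on the aryl piperazine

The compounds below may be only part of what the source reports. "The series", "measured", "known", "first", "only" and "open" are said of these compounds alone.

Within the data shown here, compound 2 `COc1cc(C)ccc1N1CCN(CCCNc2ncccc2C(=O)N(C)C)CC1` stands lowest of the two numbers so far: in a functional assay for antagonist activity at Alpha-1A adrenergic receptor (Oryctolagus cuniculus) (a higher number here means weaker binding, a lower number tighter binding), compound 2 gives 0.794 nM. Compound 1 `CN(C)C(=O)c1cccnc1NCCCN1CCN(c2ccccc2O)CC1` gives 5.01 nM in this assay, and a 6.3-fold lower number from compound 1 to compound 2 (0.80 log units; beyond the scatter). Compound 3 `Cc1ccc(N2CCN(CCCNc3ncccc3C(=O)N(C)C)CC2)c(-n2cccc2)c1` differs from compound 2 by 1H-pyrrol-1-yl in place of methoxy on an aromatic carbon. Among the measured compounds shown here, the only measured step touches the same aryl group but exchanged it entirely, so no step isolates this position; the size is uncertain. A modest weakening in this assay is expected, amounting to a 2.0-fold higher number from compound 2 to compound 3 (0.30 log units; within the scatter). Compound 3 is therefore estimated at 1.6 nM in this assay, within 0.4 nM to 6 nM.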

Compound 3, dissociation constant: 0.02 nM
Estimate against measurement, compound 3: 80-fold (1.90 log units) above; the measured number lies below the stated range.
By their numbers in this assay, from the lowest: compound 3; then compound 2; then compound 1.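

In this assay the exchange of methoxy for 1H-pyrrol-1-yl gives a 40-fold lower number from compound 2 to compound 3 (1.60 log units; beyond the scatter) and so shows that this one position, on an aromatic carbon ortho to a large group, can move the number strongly. The earlier step exchanged the whole aryl group, whereas this one isolates the position and shows that five heavy atoms with a five-membered aromatic ring are accepted there in place of two heavy atoms. Nothing available explains the tighter binding.

From the compounds shown here alone, it remains open whether the gain is specific to 1H-pyrrol-1-yl or would also appear with a phenyl, an ethoxy or a chlorine at this position.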